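Swapping the Amine Tail on a Shared Core

The source may report more compounds than this note shows. Statements on the series, on what has been measured and on what is new or still open speak of the compounds shown alone.

Compound 1 `CN1CCN(CCCCCn2c3c(c4ccccc42)C(=O)c2c[n+]([O-])c4ccccc4c2C3=O)CC1` gives 1260 nM in a functional assay on MCF7 cells (Homo sapiens) for cytotoxicity, read by MTT assay, with a stated time of 72 h; on this read-out lower numbers stand for stronger inhibition and higher numbers for weaker inhibition.
Compound 2 `CC1(C)OCC(Cn2cc(Cn3c4c(c5ccccc53)C(=O)c3c[n+]([O-])c5ccccc5c3C4=O)nn2)O1` gives 290 nM in this assay.
Compound 3 `O=C1c2c[n+]([O-])c3ccccc3c2C(=O)c2c1c1ccccc1n2Cc1cn([C@H]2O[C@H](CO)[C@@H](O)[C@H]2O)nn1` gives 1490 nM in this assay.

Among these three numbers compound 1 stands second highest. Its number and that of compound 3 lie within the usual scatter of each other, so no order between them can be claimed. Compound 2 sits clearly lower, a gap that reaches beyond the scatter.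

Compound 4 `O=C1c2c[n+]([O-])c3ccccc3c2C(=O)c2c1c1ccccc1n2CCCCN1CCCCC1` has not yet been tested in this assay. It differs from compound 1 in one place: piperidin-1-yl in place of (4-methylpiperazin-1-yl)methyl on a saturated chain carbon, four bonds along the chain from an aromatic nitrogen. Both compounds keep the same core and a saturated chain on the aromatic nitrogen; only the amine at the chain end is exchanged.

Going by the values given here, only one measured step exists, a 5.1-fold higher number from compound 2 to compound 3 (0.71 log units; beyond the scatter), and it concerns a different position, the group attached directly to the aromatic nitrogen of a triazole rather than the amine at the far end of a chain. It therefore gives no direct guide for the change from compound 1 to compound 4. In the absence of a comparable step, the expectation for compound 4 is a number close to that of compound 1, with a step of a 1.1-fold lower number from compound 1 to compound 4 (0.06 log units; within the scatter) expected, that is, none beyond the scatter. Compound 4 is estimated at 1100 nM, within a range from 400 nM to 3000 nM.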

Compound 4, half-maximal inhibitory concentration: 150 nM
Compound 4: middle estimate off by 7.3-fold (0.87 log units), on the high side; the measured number lies below the stated range.
By their numbers in this assay, from the lowest: compounds 4 and 2 (each within the scatter of the next); then compounds 1 and 3 (each within the scatter of the next).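

Going by these compounds alone, the far end of the chain turns out to matter: in this assay the exchange of amine gives an 8.4-fold lower number from compound 1 to compound 4 (0.92 log units; beyond the scatter), a step beyond the scatter and the first measured at this position, since the only earlier step concerned the group on the triazole of compounds 2 and 3. The change is also more than a swap of one ring for another. The group that leaves is (4-methylpiperazin-1-yl)methyl and the group that enters is piperidin-1-yl, and the ring goes from 2 hetero atoms to 1 and the methyl link in the name of the leaving group goes as well. No measurement here explains why this exchange lowers the number.

The compounds shown leave open whether the ring, the chain length or both account for the step, and piperidin-1-yl on the chain of compound 1, or 4-methylpiperazin-1-yl on the chain of compound 4, would pull these two apart. They also leave open how other amines at the chain end, such as morpholine or dimethylamine, would read on this same chain.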